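From furan-2-yl to 2-hydroxy-3-methoxyphenyl on the amine chain

The source may hold more compounds than are shown below. What is called first, only, known or untested is meant among the compounds shown, and "the series" means these compounds.

Compound 1 `COc1ccc(-c2ccc3c(NCCCNCc4cccc(OC)c4O)ccnc3c2)cc1`: 9.47
Compound 2 `Fc1ccc(-c2ccc3c(NCCCNCc4ccco4)ccnc3c2)cc1`: 9.47

In a physicochemical assay for acid dissociation, compound 2 gives 9.47, level with compound 1 at the digits shown, within the scatter. Compound 3 `COc1cccc(CNCCCNc2ccnc3cc(-c4ccc(F)cc4)ccc23)c1O` differs from compound 2 by 2-hydroxy-3-methoxyphenyl in place of furan-2-yl on a saturated chain carbon bound to an amine nitrogen. Going by the values given here, no step between measured compounds covers this change. Compound 1 carries the same entering group and gives 9.47, so the change is expected to leave this read-out unmoved beyond the scatter. Compound 3 is therefore estimated at 9.45, with a range from 9.1 to 9.8. The expected step, a number 0.02 log units lower from compound 2 to compound 3 (within the scatter), is none beyond the scatter.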

Compound 3, acid dissociation constant: 9.47
Compound 3: the middle estimate sits 0.02 log units below what was measured; measured number inside the range.
By their numbers in this assay, from the lowest: compounds 1, 2 and 3 (each within the scatter of the next).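

In this assay, 2-hydroxy-3-methoxyphenyl in place of furan-2-yl on a saturated chain carbon bound to an amine nitrogen gives no change at the digits printed from compound 2 to compound 3 (within the scatter), and fluoro in place of methoxy on an aromatic carbon gives no change at the digits printed from compound 1 to compound 3 (within the scatter). Compounds 1 and 2 differ in two places, so only these single changes show that neither one alone moves this read-out beyond the scatter. Nothing measured here offers an explanation for this. Still open, from the compounds shown here alone, is whether a carboxylic acid or a simple amine at this chain position would shift the number, and whether a longer chain would do so.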